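Urea series, aryl to tert-butyl isoxazole swap

A few compounds are considered here, and "the series" means these few. Any claim that something is new, unique, unknown or untested is made for them only; others in the source may bear on it.

Compound 2 `COc1ccc(NC(=O)Nc2ccc(Nc3ncnc4c3OCCN4)cc2)cc1` gives 227 nM in an assay on isolated protein for inhibition of proto-oncogene tyrosine-protein kinase receptor Ret (Homo sapiens), read by 33P incorporation, with stated times of 15 min and 40 min (a higher number here means a weaker inhibitor, a lower number a stronger inhibitor), the highest of the two numbers shown. Compound 1 `O=C(Nc1ccc(Nc2ncnc3c2OCCN3)cc1)Nc1ccc(Cl)c(C(F)(F)F)c1` gives 177 nM in this assay, which lies within the scatter of compound 2. Compound 3 `O=C(Nc1ccc(Nc2ncnc3c2OCCN3)cc1)Nc1cccc(-c2ccccc2)c1` reaches only > 10000 nM in this assay; this is a limit of the assay, not a number (the limit of > 10000 nM in this assay, at which 1 of the 3 values shown sits). Compound 4 `CC(C)(C)c1cc(NC(=O)Nc2ccc(Nc3ncnc4c3OCCN4)cc2)no1` carries 5-(tert-butyl)-1,2-oxazol-3-yl in place of 4-methoxyphenyl on an amide-type nitrogen. For the measured compounds named here, no measured pair shows a change of this kind, so the size of the step cannot be read from a neighbour. The expected step of a 2.0-fold higher number from compound 2 to compound 4 (0.30 log units; within the scatter) is modest and towards a higher number in this assay, with a real chance of no change beyond the scatter. Compound 4 is estimated at 450 nM, with a range from 120 nM to 3000 nM.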

Compound 4, half-maximal inhibitory concentration: 10 nM
The estimate for compound 4 lay 45-fold (1.65 log units) above the measured number; measured number outside the range, below it.
By their numbers in this assay, from the lowest: compound 4; then compounds 1 and 2 (each within the scatter of the next). At a limit, above all of these: compound 3.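

In this assay, for the compounds shown here, the exchange of 4-methoxyphenyl for 5-(tert-butyl)-1,2-oxazol-3-yl on the amide-type nitrogen gives a 23-fold lower number from compound 2 to compound 4 (1.36 log units; beyond the scatter) and so opens a range at this position that the earlier compounds did not reach. Compound 1 and compound 2 lie within the scatter of each other, whereas compound 4 shows that this position can respond strongly to the group it carries. No measured property at hand bears on the size of this step.

From the compounds shown here alone, whether the step belongs to the tert-butyl group or to the 1,2-oxazole ring remains open. A 5-methyl-1,2-oxazol-3-yl group, or a phenyl ring carrying tert-butyl, would separate the two.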